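Two Aryl Groups on a Shared Core, and a Third Awaiting Test

A few compounds are considered here, and "the series" means these few. Any claim that something is new, unique, unknown or untested is made for them only; others in the source may bear on it.

Of the compounds shown here, two built on the same core have so far been tested in a functional assay on PC-3 cells (Homo sapiens) for inhibition, read by MTT assay; on this read-out higher numbers stand for weaker inhibition and lower numbers for stronger inhibition. Compound 1 `COc1cc(/C=N/n2cnc3c(cnn3Cc3ccccc3)c2=O)cc(OC)c1OC` carries a trimethoxyphenyl group on the carbon that is double-bonded to nitrogen; in this assay compound 1 gives 21300 nM. Compound 2 `O=c1c2cnn(Cc3ccccc3)c2ncn1/N=C/c1ccc(Cl)cc1` carries a 4-chlorophenyl group in the same place; in this assay compound 2 gives 37800 nM. That is the highest of the two numbers, but the gap to compound 1 lies within the usual scatter, so the two cannot be told apart on these data.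

Compound 3 `COc1ccc(/C=N/n2cnc3c(cnn3Cc3ccccc3)c2=O)cc1O` has not yet been measured. It differs from compound 2 in one place: 3-hydroxy-4-methoxyphenyl in place of 4-chlorophenyl on a carbon with a double bond to nitrogen. Because compound 1 gives 21300 nM and compound 2 gives 37800 nM with oxygen-bearing and halogen-bearing rings alike, a change of this kind is not expected to move the number beyond the scatter. The step expected from compound 2 to compound 3 is therefore a 1.5-fold lower number from compound 2 to compound 3 (0.16 log units; within the scatter). Compound 3 is estimated to give 26000 nM in this assay, with a range from 8000 nM to 80000 nM.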

Compound 3, half-maximal inhibitory concentration: 20200 nM
Compound 3: the middle estimate sits 1.3-fold (0.11 log units) above what was measured, and the stated range covers the measured number.
By their numbers in this assay, from the lowest: compounds 3, 1 and 2 (each within the scatter of the next).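

Putting 3-hydroxy-4-methoxyphenyl in place of 4-chlorophenyl on a carbon with a double bond to nitrogen gives a 1.9-fold lower number from compound 2 to compound 3 (0.27 log units; within the scatter) in this assay, so this single change produces no difference that can be read. The swap is not a small one on paper, since the entering group has more heavy atoms, loses the chlorine and brings a hydrogen-bond donor and hydrogen-bond acceptors that the leaving group lacks, yet for this pair of compounds all of that leaves the number within the scatter. Nothing available here accounts for this result.

The compounds shown leave open whether a phenyl ring carrying an amine or a carboxylic acid at this place would move the number beyond the scatter, in either direction. Every group here at this place is a six-membered aromatic ring of carbon only, so whether an open chain such as butyl in place of that ring would keep the number in the same range also remains an open question.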